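This account rests on a few compounds, and the source may have more. Where it says the series, first, only, none or still open, it means among the compounds named here.

Compound 1 `C#CCOC(=O)CC1C(C(=O)OCC)=C(N)Oc2ccc(-c3cccc(N)c3)cc21` and compound 2 `C#CCOC(=O)CC1C(C(=O)OCC)=C(N)Oc2ccc(-c3cccc(NC)c3)cc21` share one core; compound 3 `C#CCOC(=O)CC1C(C(=O)OCC#C)=C(N)Oc2ccc(-c3ccc(NC)cc3)cc21` and compound 4 `C#CCOC(=O)CC1C(C(=O)OCC#C)=C(N)Oc2ccc(-c3ccc(N(C)C)cc3)cc21` share another, and the difference between the two cores is not broken down here. In a functional assay on HL-60 cells (Homo sapiens) for cytotoxicity, read by CellTiter-Blue, with a stated time of 48 h (on this read-out higher numbers stand for weaker inhibition and lower numbers for stronger inhibition), compound 1 gives 3400 nM, while compound 2 gives 7130 nM. The change from compound 1 to compound 2 is methyl in place of hydrogen on a nitrogen on an aromatic ring, and the step is a 2.1-fold higher number from compound 1 to compound 2 (0.32 log units; beyond the scatter). In this assay compound 3 gives 2450 nM; against compound 1 this lies within the scatter, against compound 2 beyond it. From compound 3 to compound 4 the change is methyl in place of hydrogen on a nitrogen on an aromatic ring, the same kind of change, though the nitrogen's other neighbours are aromatic carbon and saturated chain carbon rather than aromatic carbon alone. For compound 4 a step like the earlier one is expected, a 2.0-fold higher number from compound 3 to compound 4 (0.31 log units; beyond the scatter), because the same kind of methylation gave a 2.1-fold higher number from compound 1 to compound 2 (0.32 log units; beyond the scatter). Compound 4 is therefore estimated at 5000 nM, with a range from 2500 nM to 10000 nM.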

Compound 4, half-maximal inhibitory concentration: 2560 nM
Compound 4: the middle estimate sits 2.0-fold (0.29 log units) above what was measured; the measured number falls inside the stated range.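

In this assay, methyl in place of hydrogen on a nitrogen on an aromatic ring gives a 1.0-fold higher number from compound 3 to compound 4 (0.02 log units; within the scatter), a step that sits within the scatter, unlike the earlier one. Even so, the two steps cannot be told apart: the same change on two cores in this assay, a 2.1-fold higher number (0.32 log units; beyond the scatter) from compound 1 to compound 2 and a 1.0-fold higher number (0.02 log units; within the scatter) from compound 3 to compound 4, 2.0-fold (0.30 log units) apart, within the scatter of two such steps Carrying this change from one core to the other is therefore compatible with the data, but two pairs establish neither a fixed step size nor a rule for the series, and they do not show that the cores respond alike.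

Open, as far as these compounds go, is how a longer chain such as ethyl, or an acetyl group, on this nitrogen would read in this assay. Also open, from the compounds shown here alone, is whether a carboxylic acid in place of the amine would fit either core.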